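Replacing the Diethylamino Chain of Compound 3

The compounds below may be only part of what the source reports. "The series", "measured", "known", "first", "only" and "open" are said of these compounds alone.

Measured in a functional assay on RS4-11 cells (Homo sapiens) for inhibition, read by CCK-8 assay, with a stated time of 72 h; on this read-out higher numbers stand for weaker inhibition and lower numbers for stronger inhibition:
compound 1 `CC1(C)CCC(CN2CCN(c3ccc(C(=O)NS(=O)(=O)c4ccc(NCC5CCOCC5)c([N+](=O)[O-])c4)c(Oc4cnc5[nH]ccc5c4)c3)CC2)=C(c2cccc(C(F)(F)F)c2)C1`: 63 nM
compound 2 `CN(C)CCCNc1ccc(S(=O)(=O)NC(=O)c2ccc(N3CCN(CC4=C(c5ccc(C(F)(F)F)cc5)CC(C)(C)CC4)CC3)cc2Oc2cnc3[nH]ccc3c2)cc1[N+](=O)[O-]`: 3.9 nM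
compound 3 `CCN(CC)CCCNc1ccc(S(=O)(=O)NC(=O)c2ccc(N3CCN(CC4=C(c5ccc(C(F)(F)F)cc5)CC(C)(C)CC4)CC3)cc2Oc2cnc3[nH]ccc3c2)cc1[N+](=O)[O-]`: 3 nM

Compound 3 shares the low end of these numbers with compound 2, and compound 1 stands clearly higher. Compound 4 `CC(C)C(=O)N1CCC(CNc2ccc(S(=O)(=O)NC(=O)c3ccc(N4CCN(CC5=C(c6ccc(C(F)(F)F)cc6)CC(C)(C)CC5)CC4)cc3Oc3cnc4[nH]ccc4c3)cc2[N+](=O)[O-])CC1` has not yet been measured. Its difference from compound 3 is this: 1-(isopropylcarbonyl)piperidin-4-yl in place of 2-(diethylamino)ethyl on a saturated chain carbon bound to a nitrogen on an aromatic ring. Going by the values given here, only one measured step touches this chain: a 1.3-fold lower number from compound 2 to compound 3 (0.11 log units; within the scatter), which lies within the scatter. That step swapped one amino end group for another, whereas here the diethylamino group leaves altogether, so it guides only weakly. Compound 3 differs from compound 1 in more than one place, and compound 1 at 63 nM only warns that a higher number is possible. A modest rise is expected in this assay, a 3.3-fold higher number from compound 3 to compound 4 (0.52 log units; beyond the scatter), meaning weaker inhibition. For compound 4 the estimate is 10 nM, with an expected range of 2.5 nM to 40 nM.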

Compound 4, half-maximal inhibitory concentration: 5.3 nM
Compound 4: the middle estimate sits 1.9-fold (0.28 log units) above what was measured, and the stated range covers the measured number.
By their numbers in this assay, from the lowest: compounds 3, 2 and 4 (each within the scatter of the next); then compound 1.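

In this assay the change of chain is a 1.8-fold higher number from compound 3 to compound 4 (0.25 log units; within the scatter) and the matching change from the dimethylamino chain is a 1.4-fold higher number from compound 2 to compound 4 (0.13 log units; within the scatter) so this position on a saturated chain carbon holds its number when a bulkier group replaces the chain. The earlier step only swapped one amino end group for another, whereas here the diethylamino group leaves altogether and a piperidine ring with an isopropylcarbonyl group enters. No measurement shown explains this result. Going by these compounds, whether the piperidine amine without its isopropylcarbonyl group, a carboxylic acid or a longer chain would fit equally well stays open.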